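The source may report more compounds than this note shows. Statements on the series, on what has been measured and on what is new or still open speak of the compounds shown alone.

The measured compounds, each in a functional assay on KARPAS-299 cells (Homo sapiens) for antiproliferative activity, read by MTT assay, with a stated time of 4 h; on this read-out lower numbers stand for stronger inhibition and higher numbers for weaker inhibition:

compound 1 `COc1cc(-n2cccc2C(=O)O)ccc1Nc1ncc(Cl)c(Nc2ccccc2NS(C)(=O)=O)n1` gives 90 nM
compound 2 `COc1cc(-n2cccc2C(=O)N2CCCCC2)ccc1Nc1ncc(Cl)c(Nc2ccccc2NS(C)(=O)=O)n1` gives 1040 nM
compound 3 `COc1cc(-n2cccc2C(=O)N(C)C)ccc1Nc1ncc(Cl)c(Nc2ccccc2NS(C)(=O)=O)n1` gives 780 nM

Compound 2 is separated beyond the scatter only from compound 1, by a 12-fold higher number from compound 1 to compound 2 (1.06 log units; beyond the scatter); its value and that of compound 3 lie within the scatter of each other, as a 1.3-fold lower number from compound 2 to compound 3 (0.12 log units; within the scatter) shows. Compound 4 `CCN(CC)C(=O)c1cccn1-c1ccc(Nc2ncc(Cl)c(Nc3ccccc3NS(C)(=O)=O)n2)c(OC)c1` differs from compound 2 by diethylamino in place of piperidin-1-yl on a carbonyl carbon. Within the data shown here, the step that bears on this is the one from compound 2 to compound 3, which stayed within the scatter; the steps of a 12-fold higher number from compound 1 to compound 2 (1.06 log units; beyond the scatter) and an 8.7-fold higher number from compound 1 to compound 3 (0.94 log units; beyond the scatter) both replace hydroxy and bear on it only in that the two amides sit close together. Compound 4 is therefore expected to show no step beyond the scatter, a 1.2-fold lower number from compound 2 to compound 4 (0.06 log units; within the scatter). The estimate for compound 4 in this assay is 900 nM, within 400 nM to 2000 nM.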

Compound 4, half-maximal inhibitory concentration: 105 nM
Estimate against measurement, compound 4: 8.6-fold (0.93 log units) above, and the stated range ends above it.
By their numbers in this assay, from the lowest: compounds 1 and 4 (each within the scatter of the next); then compounds 3 and 2 (each within the scatter of the next).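

In this assay, the two amides that had sat close together do not predict a third at this carbonyl carbon: diethylamino in place of piperidin-1-yl gives a 9.9-fold lower number from compound 2 to compound 4 (1.00 log units; beyond the scatter) and diethylamino in place of dimethylamino gives a 7.4-fold lower number from compound 3 to compound 4 (0.87 log units; beyond the scatter) in the same direction. An amide here can also stay within the scatter of the carboxylic acid, as a 1.2-fold higher number from compound 1 to compound 4 (0.07 log units; within the scatter) shows, which neither compound 2 nor compound 3 did. Nothing available accounts for these steps. On these data alone, whether dipropylamino or pyrrolidin-1-yl at this carbonyl carbon would follow diethylamino or the other two amides remains open.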